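The source may report more compounds than this note shows. Statements on the series, on what has been measured and on what is new or still open speak of the compounds shown alone.

Three compounds have so far been measured in a functional assay on MCF7 cells (Homo sapiens) for antiproliferative activity, read by sulforhodamine B assay, with a stated time of 72 h, tested at 30 uM; on this read-out lower numbers stand for a stronger effect and higher numbers for a weaker effect at the one concentration tested:

compound 1, `COc1cc(Br)cc(/C=C/C(=O)c2ccccc2)c1O`, 28.1%
compound 2, `COc1cccc(C(=O)/C=C/c2cc(Br)cc(OC)c2O)c1`, 63.1%
compound 3, `COc1ccc(O)c(/C=C/C(=O)c2ccc(Cl)cc2)c1`, 29.3%

Among the compounds with values here, compound 1 stands at the low end of these numbers: compound 3 lies within the scatter of it, while compound 2 sits well above it by the only single-point step measured, a number 35 percentage points higher from compound 1 to compound 2 (beyond the scatter), a methoxy in place of hydrogen on an aromatic carbon. Compound 4, `COc1cc(Br)cc(/C=C/C(=O)c2ccc(Br)cc2)c1O`, is not yet measured; it differs from compound 1 by bromo in place of hydrogen on an aromatic carbon. Within the data shown here, no measured step involves a bromo entering, so the methoxy step does not bear directly on this change. The nearest hint is compound 3, which also carries a halogen on the ring the bromo enters and gives 29.3%, within the scatter of compound 1. On that basis the step of a number 1.9 percentage points higher from compound 1 to compound 4 (within the scatter) is expected to stay within the scatter. Compound 4 is therefore estimated at 30%, with a range from 15% to 48%.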

Compound 4, a percentage reported as activity, at one concentration (the size of the read-out at that concentration, not a potency): 48.3%
Compound 4: the middle estimate sits 18.3 percentage points below what was measured; measured number above the stated range.
By their numbers in this assay, from the lowest: compounds 1 and 3 (each within the scatter of the next); then compound 4; then compound 2.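

In this assay, the place para to a large group on this ring is not indifferent to a bromo: the change gives a number 20.2 percentage points higher from compound 1 to compound 4 (beyond the scatter) and so moves towards a weaker effect. With a number 35 percentage points higher from compound 1 to compound 2 (beyond the scatter) on the same ring, both single changes measured there go upward, and neither stays within the scatter. Nothing measured here explains this shift. The compounds shown leave open whether an amine or a carboxylic acid at this same place would also raise the number, or whether a group there could lower it.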